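Swapping the amine on the chain of compound 2

The source may hold more compounds than are shown below. What is called first, only, known or untested is meant among the compounds shown, and "the series" means these compounds.

Measured so far in an ADME assay on microsomes from liver (Rattus norvegicus) for metabolic stability, using NADPH, with a stated time of 10 min; on this read-out lower numbers stand for a less stable compound and higher numbers for a more stable compound
- Compound 1 `CCN(CC)CCCCN(C[C@H]1Cc2ncccc2CN1)[C@H]1CCCc2cccnc21` gives 6%
- Compound 2 `CN(CCCCN(C[C@H]1Cc2ncccc2CN1)[C@H]1CCCc2cccnc21)C1CCOCC1` gives 64%

Of these two, compound 2 stands higher at 64% and is the one to build on. Compound 3 `c1cnc2c(c1)CN[C@@H](CN(CCCCNC1COC1)[C@H]1CCCc3cccnc31)C2` carries (oxetan-3-yl)amino in place of methyl(oxan-4-yl)amino, on a saturated chain carbon, four bonds along the chain from an amine nitrogen: (oxetan-3-yl)amino in place of methyl(oxan-4-yl)amino on a saturated chain carbon, four bonds along the chain from an amine nitrogen. Among the compounds with values here, the only measured step at this place, a number 58 percentage points higher from compound 1 to compound 2 (beyond the scatter), shows that a swap here can matter greatly, but it gives no direction for this new swap. The expected outcome is therefore no clear change, with wide uncertainty: a number 1 percentage points higher from compound 2 to compound 3 (within the scatter). For compound 3 the estimate is 65%, with an expected range from 38% to 88%.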

Compound 3, percent of the compound remaining: 27%
Estimate against measurement, compound 3: 38 percentage points above, and the stated range ends above it.
By their numbers in this assay, from the lowest: compound 1; then compound 3; then compound 2.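

In this assay, the amine on the chain can move the result in either direction: replacing methyl(oxan-4-yl)amino with (oxetan-3-yl)amino gives up much of the earlier gain (a number 37 percentage points lower from compound 2 to compound 3 (beyond the scatter)). Even so, (oxetan-3-yl)amino still compares well with diethylamino (a number 21 percentage points higher from compound 1 to compound 3 (beyond the scatter)). No available evidence explains these differences.

This swap changes the ring from six-membered to four-membered and also adds a hydrogen-bond donor, so the compounds shown cannot separate those two changes. From the compounds shown here alone, it remains open how methyl(oxetan-3-yl)amino, which keeps the small ring but has no such donor, would behave at this place.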